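Sulfonyl aryl substituent series on the shared core

The source may hold more compounds than are shown below. What is called first, only, known or untested is meant among the compounds shown, and "the series" means these compounds.

Compound 2 `O=C1/C(=C/c2ccccc2F)CN(S(=O)(=O)c2ccc(O[N+](=O)[O-])cc2)C/C1=C\c1ccccc1F` gives 15500 nM in an ADME assay on L02 cells (Homo sapiens) for cytotoxicity, read by MTT assay, with a stated time of 24 h; a lower number here means a stronger inhibitor, a higher number a weaker inhibitor. Among the compounds with values here, this is the lowest of the two numbers so far, although it lies within the scatter of compound 1 `O=C1/C(=C/c2ccccc2F)CN(S(=O)(=O)c2ccccc2)C/C1=C\c1ccccc1F`, which in this assay gives 17600 nM. Within the data shown here, the single measured step, a 1.1-fold lower number from compound 1 to compound 2 (0.06 log units; within the scatter), is the only comparison the series offers in this assay.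

Compound 3 `O=C1/C(=C/c2ccccc2F)CN(S(=O)(=O)c2ccc(Br)cc2)C/C1=C\c1ccccc1F` has not yet been measured in this assay. It differs from compound 2 by bromo in place of nitrooxy on an aromatic carbon. Among the measured compounds shown here, no measured step exchanges nitrooxy for bromo. For the measured compounds named here, the one step that bears on this change, a 1.1-fold lower number from compound 1 to compound 2 (0.06 log units; within the scatter), alters the same aromatic carbon, para to a large group, and stays within the scatter, so nothing in the data suggests that this carbon moves the number by more than the usual spread. The expected step is therefore a 1.0-fold higher number from compound 2 to compound 3 (0.01 log units; within the scatter), without a direction beyond the scatter. Going by the values given here, the estimate for compound 3 in this assay is 16000 nM, with a range from 6000 nM to 40000 nM, the width reflecting that only one related step is available.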

Compound 3, half-maximal inhibitory concentration: 16200 nM
Beside the measured number, compound 3's estimate is 1.0-fold (0.01 log units) below it, and the stated range covers the measured number.
By their numbers in this assay, from the lowest: compounds 2, 3 and 1 (each within the scatter of the next).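

In this assay, the exchange of 4-(nitrooxy)phenyl for 4-bromophenyl gives a 1.0-fold higher number from compound 2 to compound 3 (0.02 log units; within the scatter), so this replacement stays within the scatter, even though nitrooxy, with 4 heavy atoms and 3 hydrogen-bond acceptors, gives way to bromo, with 1 heavy atom and 0 hydrogen-bond acceptors. Hydrogen on the same aromatic carbon, para to a large group, can now be compared with a second substituent, and bromo in its place gives a 1.1-fold lower number from compound 1 to compound 3 (0.04 log units; within the scatter), also within the scatter. Across compound 1, compound 2 and compound 3, all three groups at this position therefore read alike in this assay, with no compound going against that pattern, and nothing available accounts for the result.

Going by these compounds, whether an amine, a carboxylic acid or a longer chain on this aromatic carbon would also stay within the scatter remains open. Also open, on these data alone, is whether a substituent of any kind at this position can move the number beyond the scatter on the shared core.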